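Benzyl Substituent Swap on a Nucleoside Transporter Inhibitor Series

A few compounds are considered here, and "the series" means these few. Any claim that something is new, unique, unknown or untested is made for them only; others in the source may bear on it.

Three analogues of a shared core, differing only in the group carried on the saturated chain carbon bound to a nitrogen on an aromatic ring, have been tested in an assay on COS-7 cells for inhibition of sodium/nucleoside cotransporter 2 (Homo sapiens), read by scintillation counting, in the presence of a further agent that is not named here; a lower number here means a stronger inhibitor, a higher number a weaker inhibitor. Compound 1 `Nc1ncnc2c1nc(NCCCc1ccccc1)n2[C@@H]1O[C@H](CO)[C@@H](O)[C@H]1O` gives 536000 nM. Compound 2 `Cc1ccccc1CNc1nc2c(N)ncnc2n1[C@@H]1O[C@H](CO)[C@@H](O)[C@H]1O` gives 65000 nM, and compound 3 `Cc1cccc(CNc2nc3c(N)ncnc3n2[C@@H]2O[C@H](CO)[C@@H](O)[C@H]2O)c1` gives 19000 nM, the lowest of the three numbers. The steps are an 8.2-fold lower number from compound 1 to compound 2 (0.92 log units; beyond the scatter), a 28-fold lower number from compound 1 to compound 3 (1.45 log units; beyond the scatter) and a 3.4-fold lower number from compound 2 to compound 3 (0.53 log units; beyond the scatter), so moving the methyl group on the phenyl ring changed the number modestly.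

Compound 4 `Nc1ncnc2c1nc(NCc1ccc(Cl)cc1)n2[C@@H]1O[C@H](CO)[C@@H](O)[C@H]1O` differs from compound 3 in one place: 4-chlorophenyl in place of 3-methylphenyl on a saturated chain carbon bound to a nitrogen on an aromatic ring. Within the data shown here, none of the measured steps replaces a methyl group with a chlorine, so the only bearing comes from compound 2 and compound 3, where a different placement of a group on the benzyl ring gave a modest step. A comparable modest shift in this assay is therefore expected, though the direction cannot be read from the data, and a number in the range of compound 2 and compound 3 seems most likely.

On that basis compound 4 is estimated at 30000 nM, within 8000 nM to 110000 nM, which would mean a step of a 1.6-fold higher number from compound 3 to compound 4 (0.20 log units; within the scatter).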

Compound 4, half-maximal inhibitory concentration: 11000 nM
Beside the measured number, compound 4's estimate is 2.7-fold (0.44 log units) above it; low and high end bracket the measured number.
By their numbers in this assay, from the lowest: compounds 4 and 3 (each within the scatter of the next); then compound 2; then compound 1.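

In this assay, the change of 3-methylphenyl to 4-chlorophenyl on the saturated chain carbon bound to a nitrogen on an aromatic ring gives a 1.7-fold lower number from compound 3 to compound 4 (0.24 log units; within the scatter), so this position accepts a ring bearing chlorine and a ring bearing methyl with no difference that the assay can resolve. The same group stands clearly apart from the other two, with a 5.9-fold lower number from compound 2 to compound 4 (0.77 log units; beyond the scatter) and a 49-fold lower number from compound 1 to compound 4 (1.69 log units; beyond the scatter), which places compound 3 and compound 4 together, ahead of the 2-methylphenyl of compound 2 and the phenethyl of compound 1, and shows that a benzyl ring bearing chlorine keeps the gain seen with compound 3. No supporting data accompany these numbers to account for them.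

This swap alters both the group on the ring and where it sits, and the compounds shown do not separate those two changes. They also leave open how a benzyl ring carrying an amine or a carboxylic acid would read in this assay, and whether any such group would move the number beyond the scatter from compound 4.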